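The compounds below may be only part of what the source reports. "The series", "measured", "known", "first", "only" and "open" are said of these compounds alone.

In a functional assay on HL-60 cells (Homo sapiens) for antiproliferative activity, read by MTT assay, with a stated time of 72 h (a higher number here means a weaker inhibitor, a lower number a stronger inhibitor), compound 1 `CC(C)(C)c1ccc(OCCCON2C(N)=NC(N)=NC23CCSCC3)cc1` gives 280 nM, compound 2 `NC1=NC2(CCOCC2)N(OCCCOc2cccc(Cl)c2Cl)C(N)=N1` gives 440 nM, and compound 3 `NC1=NC2(CCOCC2)N(OCCCOc2ccc(F)cc2)C(N)=N1` gives 2380 nM, the highest number of the three. Compound 4 `NC1=NC2(CCOCC2)N(OCCCOc2cccc(Br)c2)C(N)=N1` differs from compound 3 as follows: 3-bromophenyl in place of 4-fluorophenyl on an oxygen on a saturated carbon. For the measured compounds named here, the only measured step at this place is a 5.4-fold higher number from compound 2 to compound 3 (0.73 log units; beyond the scatter), with 4-fluorophenyl in place of 2,3-dichlorophenyl. Going by the values given here, no measured compound carries 3-bromophenyl, so that step is a loose guide only. Run in reverse, it points to a modest move towards a lower number, probably smaller than the measured step. The expected step is a 2.6-fold lower number from compound 3 to compound 4 (0.42 log units; beyond the scatter). The estimate for compound 4 is 900 nM, with an expected range of 350 nM to 2300 nM.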

Compound 4, half-maximal inhibitory concentration: 560 nM
Compound 4: the middle estimate sits 1.6-fold (0.21 log units) above what was measured; low and high end bracket the measured number.
By their numbers in this assay, from the lowest: compounds 1, 2 and 4 (each within the scatter of the next); then compound 3.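

At this place, on an oxygen on a saturated carbon, the choice of aryl group matters in this assay: the change from 4-fluorophenyl to 3-bromophenyl gives a 4.3-fold lower number from compound 3 to compound 4 (0.63 log units; beyond the scatter). The lower number therefore does not depend on 2,3-dichlorophenyl, as 3-bromophenyl and 2,3-dichlorophenyl remain within the scatter, with a 1.3-fold higher number from compound 2 to compound 4 (0.10 log units; within the scatter). No measured evidence here explains the gap between these groups and 4-fluorophenyl.

Open, going by these compounds, is whether 4-bromophenyl or 3-fluorophenyl would separate the identity of the halogen from its ring position. Also open, on these data alone, is how unsubstituted phenyl, 3-methoxyphenyl or a pyridyl group would behave here.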